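A few compounds are considered here, and "the series" means these few. Any claim that something is new, unique, unknown or untested is made for them only; others in the source may bear on it.

Compound 1 `O=C(Nc1ccc(C(=O)N2CCCCc3sccc32)cc1O)c1ccccc1-c1ccccc1` — < 10 nM in an assay on adrenal medulla for inhibition of Vasopressin V2 receptor (Rattus norvegicus), read by radioligand binding; on this read-out lower numbers stand for stronger inhibition and higher numbers for weaker inhibition
Compound 2 `CN(C)C1CCN(C(=O)COc2cc(C(=O)N3CCCCc4sccc43)ccc2NC(=O)c2ccccc2-c2ccccc2)CC1` — 4 nM in this assay

In this assay compound 1 gives < 10 nM, which is a limit of the assay and not a number. Compound 2 gives 4 nM and holds the only number shown. The step that the limit leaves unreadable from compound 1 to compound 2 cannot be sized because the limit of < 10 nM in this assay, at which 1 of the 2 values shown sits, covers one of the two values.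

Compound 3 `CN1CCCN(C(=O)CCCOc2cc(C(=O)N3CCCCc4sccc43)ccc2NC(=O)c2ccccc2-c2ccccc2)CC1` has not yet been measured. It differs from compound 2 in one place: 2-((4-methyl-1,4-diazepan-1-yl)carbonyl)ethyl in place of (4-(dimethylamino)piperidin-1-yl)carbonyl on a saturated chain carbon bound to an oxygen on an aromatic ring. Among the compounds with values here, no measured step touches this part of the molecule, so no measured step bears on the change, and the only number available is that of compound 2. The expectation is that the step of a 1.3-fold higher number from compound 2 to compound 3 (0.10 log units; within the scatter) stays within the usual scatter. For compound 3 the estimated value in this assay is 5 nM, with a range from 1.5 nM to 20 nM.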

Compound 3, half-maximal inhibitory concentration: 3 nM
The estimate for compound 3 lay 1.7-fold (0.22 log units) above the measured number; low and high end bracket the measured number.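

In this assay, putting 2-((4-methyl-1,4-diazepan-1-yl)carbonyl)ethyl in place of (4-(dimethylamino)piperidin-1-yl)carbonyl gives a 1.3-fold lower number from compound 2 to compound 3 (0.12 log units; within the scatter). On a saturated chain carbon bound to an oxygen on an aromatic ring, then, a group with one seven-membered non-aromatic ring with 2 hetero atoms and 12 heavy atoms reads the same as one with a six-membered non-aromatic ring with 1 hetero atom and 11 heavy atoms. Compound 1 has only a limit of the assay and not a number, so the step from it cannot be read, and what either side chain adds to the shared core stays unknown: the limit of < 10 nM in this assay, at which 1 of the 3 values shown sits.

The compounds shown leave open whether the number would hold with a carboxylic acid or a morpholin-4-ylcarbonyl group at this place. They also leave open what a longer chain would do.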